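The source may report more compounds than this note shows. Statements on the series, on what has been measured and on what is new or still open speak of the compounds shown alone.

Of the compounds shown here, three have been tested in an assay on isolated protein for inhibition of alpha-ketoglutarate-dependent dioxygenase alkB homolog 3 (Homo sapiens), read by polymerase chain reaction, with a stated time of 1 h (on this read-out higher numbers stand for weaker inhibition and lower numbers for stronger inhibition), and they share a core that joins a five-membered ring to a fused two-ring system. Compound 1, with the structure `Cc1ccc2[nH]c(-n3nc(-c4ccccc4)c(-c4ccccc4)c3O)nc2c1`, gives 5800 nM in this assay, which is the higher of the two numbers that were read as numbers. The nearer neighbour is compound 3, `Cc1nn(-c2nc3ccccc3[nH]2)c(O)c1Cc1ccccc1`, which gives 480 nM in this assay, a gap that is beyond the usual scatter of repeated measurements. Compound 2, `Cc1[nH]n(-c2nc3ccccc3n2C)c(=O)c1C`, reaches only a limit of this assay, recorded as > 10000 nM, so no number is known for it; this is the case described by the limit of > 10000 nM in this assay, at which 1 of the 3 values shown sits.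

Compound 4, `Oc1c(-c2ccccc2)c(-c2ccccc2)nn1-c1nc2cc(Cl)ccc2[nH]1`, has not yet been measured in this assay. It differs from compound 1 in one place: chloro in place of methyl on an aromatic carbon. For the measured compounds named here, no measured pair shows what such a swap does here, so the expectation rests only on the size of the change, a single heavy atom for another with no ring, donor or acceptor count altered. The step from compound 1 to compound 4 is expected to be small, within or only just beyond the scatter, a 1.3-fold lower number from compound 1 to compound 4 (0.11 log units; within the scatter). Compound 4 is therefore estimated to give about 4500 nM in this assay, with a likely range from 1500 nM to 12000 nM.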

Compound 4, half-maximal inhibitory concentration: 2000 nM
Compound 4: middle estimate off by 2.3-fold (0.35 log units), on the high side; measured number inside the range.
By their numbers in this assay, from the lowest: compound 3; then compound 4; then compound 1. At a limit, above all of these: compound 2.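

For the compounds shown here, this pair is the only one so far that differs in a single place, so it gives the first direct reading of one change on the shared core. In this assay, chloro in place of methyl on this aromatic carbon gives a 2.9-fold lower number from compound 1 to compound 4 (0.46 log units; beyond the scatter), showing that the number responds to exchanging one heavy atom for another, even though the counts of rings, donors and acceptors stay the same. The data shown offer no explanation for this modest step.

Going by these compounds, whether a methoxy group, a nitrile or an amine on the same carbon would move the number further, and in which direction, remains open. On these data alone, it is also open whether the same swap would give a similar step on a core carrying different groups on its five-membered ring.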